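From chloro to 4-methylpiperazin-1-yl in compound 3

A few compounds are considered here, and "the series" means these few. Any claim that something is new, unique, unknown or untested is made for them only; others in the source may bear on it.

Measured in a functional assay on Bel-7402 cells (Homo sapiens) for cytotoxicity, read by MTT assay, with a stated time of 48 h; a higher number here means a weaker inhibitor, a lower number a stronger inhibitor:
Compound 1 `CCn1cc(-c2nc3ccccc3o2)c(=O)c2cc(F)c(N3CCN(C)CC3)cc21`: 2000 nM
Compound 2 `CCn1cc(-c2nc3ccc([N+](=O)[O-])cc3o2)c(=O)c2cc(F)c(Cl)cc21`: 1800 nM

In this assay, compound 2 at 1800 nM lies within the scatter of compound 1 at 2000 nM, so the two cannot be ranked. Compound 3 `CCn1cc(-c2nc3ccc([N+](=O)[O-])cc3o2)c(=O)c2cc(F)c(N3CCN(C)CC3)cc21` has 4-methylpiperazin-1-yl in place of chloro on an aromatic carbon of compound 2 (4-methylpiperazin-1-yl in place of chloro on an aromatic carbon). Among the compounds with values here, no measured pair isolates this change. Compound 1 carries the same 4-methylpiperazin-1-yl group and gives 2000 nM, so no large shift is expected. The expected step of a 1.4-fold lower number from compound 2 to compound 3 (0.14 log units; within the scatter) is small, leaning slightly towards a lower number. The estimate for compound 3 is 1300 nM, with an expected range of 450 nM to 3800 nM.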

Compound 3, half-maximal inhibitory concentration: 50200 nM
Estimate against measurement, compound 3: 39-fold (1.59 log units) below; measured number outside the range, above it.
By their numbers in this assay, from the lowest: compounds 2 and 1 (each within the scatter of the next); then compound 3.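

In this assay, 4-methylpiperazin-1-yl in place of chloro on this aromatic carbon is a large loss when the nitro group is present, with a 28-fold higher number from compound 2 to compound 3 (1.45 log units; beyond the scatter). Nitro in place of hydrogen is likewise a large loss when 4-methylpiperazin-1-yl is present, with a 25-fold higher number from compound 1 to compound 3 (1.40 log units; beyond the scatter). Compound 1 and compound 2 each carry one of these groups and cannot be ranked, so only compound 3, which carries both, shows this loss.

Nothing at hand bears on the reason for it. On these data alone, it remains open whether morpholin-4-yl at this carbon, or an amino group in place of nitro, would give the same loss.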